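A few compounds are considered here, and "the series" means these few. Any claim that something is new, unique, unknown or untested is made for them only; others in the source may bear on it.

Measured compounds in an assay on cells (Endothelial cell) for binding affinity to Endothelin-1 receptor (Sus scrofa); on this read-out lower numbers stand for stronger inhibition and higher numbers for weaker inhibition:
compound 1 `Cc1ccc(-c2c(NS(=O)(=O)c3ccc(C(C)C)cc3)ncnc2OCCOc2ncc(Br)cn2)cc1` gives 0.16 nM
compound 2 `Cc1ccc(-c2c(NS(=O)(=O)c3ccc(Br)cc3)ncnc2OCCOc2ncc(Br)cn2)cc1` gives 2.8 nM
compound 3 `Cc1ccc(-c2c(NS(=O)(=O)c3ccc(I)cc3)ncnc2OCCOc2ncc(Br)cn2)cc1` gives 1 nM

Compound 3 stands second highest of the three numbers: the step of a 6.3-fold higher number from compound 1 to compound 3 (0.80 log units; beyond the scatter) lies beyond the scatter, as does the step of a 2.8-fold lower number from compound 2 to compound 3 (0.45 log units; beyond the scatter). The unmeasured compound 4 `Cc1ccc(-c2c(NS(=O)(=O)c3ccc(C(F)(F)F)cc3)ncnc2OCCOc2ncc(Br)cn2)cc1` differs from compound 3 by trifluoromethyl in place of iodo on an aromatic carbon. The two steps that bear on this position are the ones just named, where isopropyl gave the lowest number and bromo the highest, with iodo in between. Trifluoromethyl enters with four heavy atoms, more than iodo, so compound 4 is expected to land between compound 3 and compound 1, a step of a 2.0-fold lower number from compound 3 to compound 4 (0.30 log units; within the scatter). The estimate for compound 4 is 0.5 nM, with a range from 0.15 nM to 1.8 nM.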

Compound 4, half-maximal inhibitory concentration: 1.4 nM
Compound 4: the middle estimate sits 2.8-fold (0.45 log units) below what was measured, and the stated range covers the measured number.
By their numbers in this assay, from the lowest: compound 1; then compounds 3, 4 and 2 (each within the scatter of the next, the first and the last beyond it).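

In this assay, trifluoromethyl at this position cannot be told apart from either halogen, with a 1.4-fold higher number from compound 3 to compound 4 (0.15 log units; within the scatter) and a 2.0-fold lower number from compound 2 to compound 4 (0.30 log units; within the scatter) both printed within the scatter. Isopropyl remains clearly apart, with an 8.8-fold higher number from compound 1 to compound 4 (0.94 log units; beyond the scatter), so the larger count of heavy atoms in trifluoromethyl does not bring compound 4 to the level of compound 1. Nothing available explains this difference. Still open, going by these compounds, is how a tert-butyl group, a methoxy group or an amine on this aromatic carbon would compare with isopropyl.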